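Thiourea cytotoxicity: from bromophenyl to acetyl

The source may report more compounds than this note shows. Statements on the series, on what has been measured and on what is new or still open speak of the compounds shown alone.

Compound 1 `FC(F)(F)c1cccc(NC(=S)Nc2ccc(Cl)cc2)c1`: 10000 nM
Compound 2 `C=C(C)CNC(=S)Nc1cccc(C(F)(F)F)c1`: > 100000 nM, a limit of the assay rather than a number
Compound 3 `FC(F)(F)c1cccc(NC(=S)Nc2ccccc2Br)c1`: 59000 nM

In an ADME assay on BHK cells (Mesocricetus auratus) for cytotoxicity, read by MTT assay, with a stated time of 96 h (a higher number here means that more compound is tolerated, a lower number that less compound is tolerated), compound 3 gives the highest of the two numbers seen; compound 1 sits nearest, with a 5.9-fold higher number from compound 1 to compound 3 (0.77 log units; beyond the scatter). Compound 2 gives only a limit, (the limit of > 100000 nM in this assay, at which 1 of the 3 values shown sits). Compound 4 `CC(=O)NC(=S)Nc1cccc(C(F)(F)F)c1` is not yet measured; it differs from compound 3 by acetyl in place of 2-bromophenyl on an amide-type nitrogen. The step that bears most on this also swaps a phenyl-type group on that nitrogen for a small chain: an at least 10-fold higher number from compound 1 to compound 2 (1.00 log units; beyond the scatter). The comparison an at least 1.6-fold lower number from compound 2 to compound 3 (0.22 log units; that floor lies within the scatter) points the same way. An increase beyond the scatter is therefore expected for compound 4, a 1.7-fold higher number from compound 3 to compound 4 (0.23 log units; within the scatter). Compound 4 is estimated at 100000 nM, within 40000 nM to 250000 nM.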

Compound 4, half-maximal cytotoxic concentration: > 100000 nM
Compound 4 ended at the assay's limit; the forecaster's own chance of this, stated with the estimate: 55%; the middle value sits exactly at the limit.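

Replacing 4-chlorophenyl on this nitrogen with acetyl gives an at least 10-fold higher number from compound 1 to compound 4 (1.00 log units; beyond the scatter), so a second small group without a ring, this one carrying a carbonyl, ends up at the same limit as the 2-methylprop-2-en-1-yl of compound 2. Against 2-bromophenyl the result is less clear, with an at least 1.6-fold higher number from compound 3 to compound 4 (0.22 log units; that floor lies within the scatter), so acetyl and that ring are not separated here. Compound 2 and compound 4 cannot be ranked, and the step between them cannot be read: the limit of > 100000 nM in this assay, at which 2 of the 4 values shown sit.

Going by these compounds, how much compound the cells would tolerate with either small group stays unknown. On these data alone, whether an amine or a longer chain on this nitrogen would also reach the limit remains open.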